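Liver microsome half-life: an azetidine in place of a methyl

A few compounds are considered here, and "the series" means these few. Any claim that something is new, unique, unknown or untested is made for them only; others in the source may bear on it.

Three compounds sharing one core have been run in an ADME assay on microsomes from liver (Mus musculus, strain CD-1) for metabolic stability, read by LC-MS, tested at 2 uM; a higher number here means that the compound lasts longer, a lower number that the compound disappears faster. Compound 1 `CNS(=O)(=O)c1ccccc1Nc1cc(-c2ccc3ccn(C)c3c2)c2nccnc2c1` gives 0.2 h. Among the compounds with values here, compound 2 `Cn1cc(CNS(=O)(=O)c2ccccc2Nc2cc(-c3ccc4ccn(C)c4c3)c3nccnc3c2)cn1` gives 0.267 h; the only measured step, a 1.3-fold higher number from compound 1 to compound 2 (0.13 log units; within the scatter), changes nothing beyond the scatter. Compound 3 `CNC(=O)c1ccncc1Nc1cc(-c2ccc3ccn(C)c3c2)c2nccnc2c1` gives 0.45 h, which lies within the scatter of compound 2 and beyond the scatter from compound 1, so on the numbers seen so far compound 3 is the one that separates clearly from compound 1 only.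

Compound 4 `CN1CC(NC(=O)c2ccncc2Nc2cc(-c3ccc4ccn(C)c4c3)c3nccnc3c2)C1` is not yet measured. It differs from compound 3 by 1-methylazetidin-3-yl in place of methyl on an amide-type nitrogen. Within the data shown here, the one measured step that bears on it is the one from compound 1 to compound 2, where a 1-methyl-1H-pyrazol-4-yl ring entered in place of hydrogen at a different position, and that step stayed within the scatter. Nothing in the present data shows a ring entering on a nitrogen moving the number beyond the scatter, so the step from compound 3 to compound 4 is expected to be small, no change at the digits printed from compound 3 to compound 4 (within the scatter), with no clear direction. Compound 4 is therefore estimated at 0.45 h, with a likely range from 0.22 h to 0.9 h.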

Compound 4, half-life: > 1 h
Compound 4 ended at the assay's limit (the forecaster's own chance of this, stated with the estimate: 5%); middle value at least 2.2-fold (0.34 log units) from the limit.
By their numbers in this assay, from the lowest: compounds 1, 2 and 3 (each within the scatter of the next, the first and the last beyond it). At a limit, above all of these: compound 4.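

In this assay, within the data shown here, the swap of methyl for 1-methylazetidin-3-yl on the amide-type nitrogen gives an at least 2.2-fold higher number from compound 3 to compound 4 (0.34 log units; beyond the scatter), while the only earlier step, a 1.3-fold higher number from compound 1 to compound 2 (0.13 log units; within the scatter), involved a different group at a different place and did not clear the scatter. Compound 4 gives > 1 h, which is a limit of the assay and not a number. This position on the amide-type nitrogen is therefore one where the half-life responds to the group carried there, although the full size of the step stays unknown and the printed step gives only its lower bound, with the reading resting on this: the limit of > 1 h in this assay, at which 1 of the 4 values shown sits.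

The compounds shown do not separate the four-membered ring from its nitrogen or from the methyl on that nitrogen, so it remains open whether an azetidin-3-yl group without that methyl, a cyclobutyl group with no ring nitrogen, or an open chain such as 2-(dimethylamino)ethyl would give a similar half-life. From the compounds shown here alone, it is also open whether 1-methylazetidin-3-yl would have the same effect on the sulfonamide nitrogen of compound 1.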